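This account rests on a few compounds, and the source may have more. Where it says the series, first, only, none or still open, it means among the compounds named here.

Working notes on the series. All three measured compounds share one core and differ only in the group on the aromatic carbon next to the ring nitrogen. In a functional assay on HEK293 cells for activation of melanin-concentrating hormone receptor 1 (Homo sapiens), read by inositol phosphate accumulation (a lower number here means that less compound is needed, a higher number that more compound is needed for the effect), compound 1 `CC(C)(C)c1cc(N)c2cc(NC(=O)/C=C/c3ccc(C(F)(F)F)cc3)ccc2n1` gives 29 nM. In this assay compound 2 `Nc1cc(C2CCC2)nc2ccc(NC(=O)/C=C/c3ccc(C(F)(F)F)cc3)cc12` gives 250 nM. In this assay compound 3 `Nc1cc(C2CCCCC2)nc2ccc(NC(=O)/C=C/c3ccc(C(F)(F)F)cc3)cc12` gives 96 nM. Compound 3 thus stands second highest of the three numbers: a 3.3-fold higher number from compound 1 to compound 3 (0.52 log units; beyond the scatter), while a 2.6-fold lower number from compound 2 to compound 3 (0.42 log units; beyond the scatter). The next step leads to compound 4 `CCc1cc(N)c2cc(NC(=O)/C=C/c3ccc(C(F)(F)F)cc3)ccc2n1`, where the change is ethyl in place of cyclohexyl on an aromatic carbon. Among the measured compounds shown here, the steps that bear on it are an 8.6-fold higher number from compound 1 to compound 2 (0.94 log units; beyond the scatter) and a 3.3-fold higher number from compound 1 to compound 3 (0.52 log units; beyond the scatter), both showing a higher number when the tert-butyl group is exchanged for a ring, and a 2.6-fold lower number from compound 2 to compound 3 (0.42 log units; beyond the scatter). The ethyl group brings fewer heavy atoms than any of the groups measured so far, so the number for compound 4 is expected to rise beyond the scatter; the size of that rise is uncertain since no smaller group has been measured. The expected step is a 3.1-fold higher number from compound 3 to compound 4 (0.49 log units; beyond the scatter). Compound 4 is estimated at 300 nM, expected to fall between 80 nM and 1200 nM.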

Compound 4, half-maximal effective concentration: 110 nM
Compound 4: the middle estimate sits 2.7-fold (0.44 log units) above what was measured; the range from low to high includes it.
By their numbers in this assay, from the lowest: compound 1; then compounds 3 and 4 (each within the scatter of the next); then compound 2.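

In this assay the change from cyclohexyl to ethyl on the aromatic carbon next to the ring nitrogen goes from 6 heavy atoms and a ring to 2 heavy atoms and no ring, yet it reads as a 1.1-fold higher number from compound 3 to compound 4 (0.06 log units; within the scatter), so a ring is not needed here to match cyclohexyl. Ethyl also gives a lower number than cyclobutyl, with a 2.3-fold lower number from compound 2 to compound 4 (0.36 log units; beyond the scatter), and that places compound 2 against any ordering of this position by group size. Compound 1 still holds the lowest number, with a 3.8-fold higher number from compound 1 to compound 4 (0.58 log units; beyond the scatter), so tert-butyl stays ahead of the open chain as well as of both rings.

As far as these compounds go, whether isopropyl, methyl, a longer chain such as propyl or an amine would come close to tert-butyl at this position remains open. Nothing on hand accounts for any of these steps.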